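The source may hold more compounds than are shown below. What is called first, only, known or untested is meant among the compounds shown, and "the series" means these compounds.

Measured so far in an assay on isolated protein for agonist activity at Bile acid receptor (Homo sapiens), read by AlphaScreen, with a stated time of 30 min; on this read-out higher numbers stand for an effect only at larger amounts of compound and lower numbers for an effect already at smaller amounts:
compound 1 `Cc1ccccc1-n1nc(C)c2c1NC(=O)[C@H](C)S[C@@H]2c1ccc(-c2cccc(C(=O)O)c2)cc1`: "not active" (no number reported)
compound 2 `Cc1nn(-c2ccccc2Cl)c2c1C(c1ccc(Oc3ccccc3)cc1)SC(C)C(=O)N2`: 2700 nM
compound 3 `Cc1nn(-c2ccccc2C(F)(F)F)c2c1C(c1ccc(Oc3ccccc3)cc1)SC(C)C(=O)N2`: 2000 nM

Compound 1 stands apart. In this assay compound 1 gives "not active" (no number reported), a result without a number, so it cannot be ranked against compounds 2 and 3, both of which give measurable numbers. Going by the values given here, the only step among measured compounds, a 1.4-fold lower number from compound 2 to compound 3 (0.13 log units; within the scatter), concerns a different part of the shared core and lies within the scatter, so it offers no guidance on the change studied here.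

Compound 4 `COc1ccc(Oc2ccc([C@H]3S[C@@H](C)C(=O)Nc4c3c(C)nn4-c3ccccc3C)cc2)cc1` differs from compound 1 by 4-methoxyphenoxy in place of 3-carboxyphenyl on an aromatic carbon. Among the compounds with values here, no measured step covers this change. Within the data shown here, what bears on it is only that compounds 2 and 3, which carry a phenoxy group in the same place on the aromatic ring, give numbers in this assay, while compound 1, with 3-carboxyphenyl there, gives none. The 4-methoxyphenoxy group of compound 4 is closer in build to that phenoxy group than to 3-carboxyphenyl. Compound 4 is therefore expected to move from no measurable activity to a number comparable with those of compounds 2 and 3, though compound 4 also differs from them in another group, so the uncertainty is wide. Compound 4 is estimated at 2500 nM, with a range from 700 nM to 9000 nM.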

Compound 4, half-maximal effective concentration: 2200 nM
Compound 4: middle estimate off by 1.1-fold (0.06 log units), on the high side, within the range that was stated.
By their numbers in this assay, from the lowest: compounds 3, 4 and 2 (each within the scatter of the next).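

No step can be read from compound 1 to compound 4: in this assay compound 1 gives "not active" (no number reported) and compound 4 gives 2200 nM and a result without a number allows no size of change. The compounds shown leave open how 4-methoxyphenoxy compares with phenoxy on an otherwise unchanged structure. No measured evidence bears on this result.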